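Adding a Hydroxypropoxy Chain to a Weak Nitrile Inhibitor

The compounds below may be only part of what the source reports. "The series", "measured", "known", "first", "only" and "open" are said of these compounds alone.

Measured compounds:
compound 1, `N#Cc1nccc(-c2ccc(OCCCO)c(C(F)(F)F)c2)n1`: 4.5 nM
compound 2, `N#Cc1cccc(-c2cccc(C(F)(F)F)c2)n1`: 2880 nM

Of the compounds shown here, two have been tested in an assay on isolated protein for inhibition of cathepsin S (Homo sapiens), read by fluorescence; a lower number here means a stronger inhibitor, a higher number a weaker inhibitor. Compound 1, `N#Cc1nccc(-c2ccc(OCCCO)c(C(F)(F)F)c2)n1`, gives 4.5 nM in this assay. For the measured compounds named here, compound 2, `N#Cc1cccc(-c2cccc(C(F)(F)F)c2)n1`, gives 2880 nM and so stands highest of the two numbers; compound 1 is its only neighbour and sits far lower, well beyond the scatter. Going by the values given here, the two compounds differ both in their core and in the substitution of the outer ring, so no single step between them can be isolated.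

Compound 3, `N#Cc1cccc(-c2ccc(OCCCO)c(C(F)(F)F)c2)n1`, keeps the core of compound 2 and carries the change (3-hydroxypropoxy in place of hydrogen on an aromatic carbon), that is, 3-hydroxypropoxy in place of hydrogen on an aromatic carbon. With this group compound 3 shares the outer ring of compound 1 while retaining the core of compound 2. Since compound 1 gives 4.5 nM, the added chain is expected to lower the number considerably, though part of the gap may belong to the core. The step from compound 2 to compound 3 is estimated at a 72-fold lower number from compound 2 to compound 3 (1.86 log units; beyond the scatter). For compound 3 the expected value in this assay is 40 nM, within a range of 6 nM to 300 nM.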

Compound 3, half-maximal inhibitory concentration: 155 nM
The estimate for compound 3 lay 3.9-fold (0.59 log units) below the measured number; the measured number falls inside the stated range.
By their numbers in this assay, from the lowest: compound 1; then compound 3; then compound 2.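

In this assay, putting 3-hydroxypropoxy in place of hydrogen on an aromatic carbon, ortho to a trifluoromethyl group, gives a 19-fold lower number from compound 2 to compound 3 (1.27 log units; beyond the scatter) with the core left unchanged. For the compounds shown here, this is the first reading of this position on its own, and it shows that the chain alone is enough to produce a large step, beyond the scatter, on the core of compound 2. Yet the chain does not account for the whole gap between the earlier compounds: with the same outer ring, compound 3 gives 155 nM and compound 1 gives 4.5 nM, so a difference in these printed values remains that goes with the core. Nothing measured here explains why the chain has this effect.

On these data alone, it remains open whether the whole chain is needed, or whether a methoxy group, a longer chain or a chain ending in an amine or a carboxylic acid would give a similar number at this position. As far as these compounds go, it is also open how large the step from the same chain would be on the core of compound 1.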